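A few compounds are considered here, and "the series" means these few. Any claim that something is new, unique, unknown or untested is made for them only; others in the source may bear on it.

The series is built on a shared core, and compound 1 (`O=C1C=C(N2CCC2)C(=O)c2c1nc1n2[C@H]2OC[C@@H](O)[C@H]2OC1`) carries an azetidin-1-yl group on it. In a functional assay on HeLa cells (Homo sapiens) for inhibition, read by sulforhodamine B assay (on this read-out higher numbers stand for weaker inhibition and lower numbers for stronger inhibition), compound 1 gives > 16000 nM, which is a limit of the assay and not a number. Its standing is therefore known only as this limit.

Compound 2 (`O=C1C(Nc2ccc(C(F)(F)F)cc2)=CC(=O)c2c1nc1n2[C@H]2OC[C@@H](O)[C@H]2OC1`) bears a phenylamino group with a trifluoromethyl substituent, and in this assay compound 2 gives a true number, 8920 nM. For the measured compounds named here, no single-place step connects these two compounds, so the data do not directly show the effect of any one change.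

Compound 3 (`O=C1C=C(Nc2ccc(Br)cc2)C(=O)c2c1nc1n2[C@H]2OC[C@@H](O)[C@H]2OC1`) is the next case. It has (4-bromophenyl)amino in place of azetidin-1-yl on a double-bonded ring carbon.

A moderate shift toward stronger inhibition is expected, resting on compound 2, which reaches a measured 8920 nM with its own phenylamino group. This is only an expectation, and compound 3 may also end up reported as a limit. The estimated change is an at least 2.0-fold lower number from compound 1 to compound 3 (0.30 log units; that floor lies within the scatter).

In this assay, the estimate for compound 3 is 8000 nM, with an expected range from 2500 nM to 20000 nM.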

Compound 3, half-maximal inhibitory concentration: 3830 nM
For compound 3 the middle estimate is 2.1-fold (0.32 log units) above the measured one, and the stated range covers the measured number.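

Setting (4-bromophenyl)amino in place of azetidin-1-yl on a double-bonded ring carbon gives an at least 4.1-fold lower number from compound 1 to compound 3 (0.62 log units; beyond the scatter), the first single-place step available in the series, and it shows that inhibition in this assay responds to the group at this position. Only a floor can be given for the size of that step, because compound 1 stands at a limit of the assay and not at a number: the limit of > 16000 nM in this assay, at which 1 of the 3 values shown sits. With compound 3 at 3830 nM, a true number, this position now has a measured reference against which other groups on the same carbon can be compared.

The step exchanges the four-membered ring for a six-membered aromatic ring, adds a hydrogen-bond donor and brings in bromine all at once, so the compounds shown cannot assign the shift to any one of these parts. Going by these compounds, it remains open how a plain phenylamino group, with hydrogen in place of the bromine, or a non-aromatic amine such as morpholin-4-yl would stand at this carbon.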